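Replacing the bicyclic group in compound 2 with a smaller ring

This account rests on a few compounds, and the source may have more. Where it says the series, first, only, none or still open, it means among the compounds named here.

Of the compounds shown here, two have been measured so far. Compound 1 `FC(F)(F)c1ncnc2c1ncn2C1COc2ccccc2CO1` gives 1250 nM in a functional assay on MCF7 cells (Homo sapiens) for antiproliferative activity; on this read-out higher numbers stand for weaker inhibition and lower numbers for stronger inhibition. Compound 2 `O=[N+]([O-])c1ccc(S(=O)(=O)N2CC(n3cnc4ncnc(Cl)c43)OCc3ccccc32)cc1` gives 1220 nM in this assay; this is the lower of the two numbers, but the gap to compound 1 lies within the scatter, so the two compounds stand level. Compound 3 `O=c1cc[nH]c(=O)n1C1CN(S(=O)(=O)c2ccc([N+](=O)[O-])cc2)c2ccccc2CO1` has not been measured. It differs from compound 2 in one place: a group of 8 heavy atoms (4 carbon, 2 nitrogen, 2 oxygen; one six-membered aromatic ring with 2 hetero atoms) in place of a group of 10 heavy atoms (5 carbon, 4 nitrogen, 1 chlorine; one five-membered aromatic ring with 2 hetero atoms, one six-membered aromatic ring with 2 hetero atoms), on a saturated ring carbon. Among the compounds with values here, no measured pair shows this exchange, so its effect is not known from the data; the group entering is smaller, with one hydrogen-bond donor where the leaving group had none, and one acceptor fewer. The step of a 4.1-fold higher number from compound 2 to compound 3 (0.61 log units; beyond the scatter) is expected to be a loss, beyond the scatter. Compound 3 is therefore estimated at 5000 nM, with a range from 1500 nM to 20000 nM.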

Compound 3, half-maximal inhibitory concentration: 44300 nM
Compound 3: the middle estimate sits 8.9-fold (0.95 log units) below what was measured; measured number above the stated range.
By their numbers in this assay, from the lowest: compounds 2 and 1 (each within the scatter of the next); then compound 3.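

In this assay, the exchange on the saturated ring carbon next to the ring oxygen is a large loss (a 36-fold higher number from compound 2 to compound 3 (1.56 log units; beyond the scatter)). Within the data shown here, this is the first sign that the read-out responds strongly to the group at this position: the core is unchanged, yet a single exchange moves the number far beyond the scatter. The exchange alters several things at once, including the five-membered aromatic ring, the chlorine, the two double bonds outside aromatic rings and the hydrogen-bond donor, and no measurement shown bears on which of these matters.

Among these compounds, it remains open which of these changes accounts for the loss, since only one exchange at this position can be read. On these data alone, it is also open whether an amine in place of the chlorine of compound 2 would hold the number or lose it as well.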